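Notes on compound 4 and the amine-ring exchange

The source may hold more compounds than are shown below. What is called first, only, known or untested is meant among the compounds shown, and "the series" means these compounds.

The series shares one core. Compound 2 is `Fc1cccc(Nc2nc3nonc3nc2Nc2ccccc2F)c1`, compound 3 is `Fc1ccccc1Nc1nc2nonc2nc1Nc1cccc(OC(F)(F)F)c1` and compound 1 is `Cc1ccc(Nc2nc3nonc3nc2Nc2ccc(C)c(C)c2)cc1C`. In an assay on mitochondria from L6 cells (Rattus norvegicus) for activation, with a stated time of 90 min (a higher number here means that more compound is needed for the effect, a lower number that less compound is needed), compound 2 gives 190 nM. In this assay compound 3 gives 600 nM. Compound 1 reaches only a limit in this assay, > 100000 nM; that is the limit of > 100000 nM in this assay, at which 1 of the 3 values shown sits. Of the two numbers, compound 2 stands lowest; its nearest neighbour is compound 3, reached by a 3.2-fold higher number from compound 2 to compound 3 (0.50 log units; beyond the scatter).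

Compound 4 is `Fc1ccccc1Nc1nc2nonc2nc1Nc1ccccn1`. It differs from compound 2 in one place: pyridin-2-yl in place of 3-fluorophenyl on a nitrogen on an aromatic ring.

Going by the values given here, no measured pair exchanges a phenyl ring for a pyridin-2-yl ring, so nothing bears directly on this change. Among the compounds with values here, the only measured step, a 3.2-fold higher number from compound 2 to compound 3 (0.50 log units; beyond the scatter), alters a substituent on an aromatic carbon and shows that a change on one of the amine-linked rings moves the number modestly rather than far. An exchange of the whole ring is a larger alteration than a substituent swap, so a somewhat larger but still modest upward step is the working expectation, with wide uncertainty in both directions. Compound 4 is thus expected to show a 2.6-fold higher number from compound 2 to compound 4 (0.42 log units; beyond the scatter). Compound 4 is expected at 500 nM in this assay, within a range of 120 nM to 3000 nM.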

Compound 4, half-maximal effective concentration: 9000 nM
Estimate against measurement, compound 4: 18-fold (1.26 log units) below; measured number outside the range, above it.
By their numbers in this assay, from the lowest: compound 2; then compound 3; then compound 4. At a limit, above all of these: compound 1.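

The nitrogen that carries 3-fluorophenyl in compound 2 tolerates a whole-ring exchange far less well than a substituent change on that ring: in this assay, pyridin-2-yl gives a 47-fold higher number from compound 2 to compound 4 (1.68 log units; beyond the scatter), against a 3.2-fold higher number from compound 2 to compound 3 (0.50 log units; beyond the scatter) for trifluoromethoxy in place of fluoro. The position is therefore sensitive to the identity of the ring itself, and the modest earlier step did not reveal this. The exchange changes several things at once, since a carbon-only ring bearing fluorine leaves and a ring with one hetero atom and one hydrogen-bond acceptor enters, and nothing available on the compounds bears on which of these accounts for the rise.

From the compounds shown here alone, whether the rise follows the ring nitrogen or the loss of the fluorine stays open, and an unsubstituted phenyl ring or a pyridin-3-yl ring on the same nitrogen would help separate the two. Also open, going by these compounds, is whether a pyridin-2-yl ring carrying a fluoro or methyl group recovers any of the loss, as the other amine-linked ring is the same in compound 2, compound 3 and compound 4.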